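This account rests on a few compounds, and the source may have more. Where it says the series, first, only, none or still open, it means among the compounds named here.

In a physicochemical assay for solubility (on this read-out higher numbers stand for higher solubility and lower numbers for lower solubility), compound 3 `CNC(=O)c1cc(C(=O)NC2CC2)cn(Cc2cccc3cn[nH]c23)c1=O` gives only a limit, >= 181 ug/mL, and not a number. Compound 4 `CNC(=O)c1cc(C(=O)NC2CC2)cn(Cc2cccc(OC)c2)c1=O` has not yet been measured, and the change to it is 3-methoxyphenyl in place of 1H-indazol-7-yl on a saturated chain carbon bound to an aromatic nitrogen. Compound 2 `CNC(=O)c1cc(C(=O)NC2CC2)cn(Cc2cccc3[nH]ccc23)c1=O` reads 78 ug/mL. The measured steps show an at least 2.3-fold higher number from compound 2 to compound 3 (0.36 log units; beyond the scatter), alongside an at least 1.7-fold lower number from compound 1 to compound 2 (0.23 log units; that floor lies within the scatter) and a step that the two limits leave unreadable from compound 1 to compound 3. Compound 4 is closest to compound 1 `CNC(=O)c1cc(C(=O)NC2CC2)cn(Cc2cccc(F)c2)c1=O`, which also carries a phenyl group, and compound 1 gives only a limit of >= 133 ug/mL. In this assay only a small fall, or none beyond the scatter, is therefore expected, and the expected step is an at least 1.5-fold lower number from compound 3 to compound 4 (0.17 log units; that floor lies within the scatter). For compound 4 the estimated value is 120 ug/mL, with an expected range of 55 ug/mL to 230 ug/mL.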

Compound 4, solubility: 79 ug/mL
The estimate for compound 4 lay 1.5-fold (0.18 log units) above the measured number, within the range that was stated.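

In this assay, 3-methoxyphenyl and 1H-indol-4-yl read alike, with a 1.0-fold higher number from compound 2 to compound 4 (0.01 log units; within the scatter), while the other comparison gives an at least 2.2-fold lower number from compound 3 to compound 4 (0.36 log units; beyond the scatter). At this place, on a saturated chain carbon bound to an aromatic nitrogen, 1H-indazol-7-yl therefore stands apart from both groups, where earlier it had a readable step only against 1H-indol-4-yl. Methoxy in place of fluoro on an aromatic carbon gives an at least 1.6-fold lower number from compound 1 to compound 4 (0.22 log units; that floor lies within the scatter), so this change shows no step beyond the scatter.

As far as these compounds go, compound 1 and compound 3 give limits rather than numbers, so the full size of their steps stays open. How an amine or a carboxylic acid in place of methoxy would read in this assay also stays open, and nothing shown here bears on the cause of these steps.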